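Side-chain variation on a naphthoquinone-type core: a small extension

The compounds below may be only part of what the source reports. "The series", "measured", "known", "first", "only" and "open" are said of these compounds alone.

Measured compounds:
- compound 1 `COC(C)CO[C@H](CC=C(C)C)C1=CC(=O)c2c(O)ccc(O)c2C1=O`: 53400 nM
- compound 2 `CCCCC(O)CC(=O)O[C@H](CC=C(C)C)C1=CC(=O)c2c(O)ccc(O)c2C1=O`: 72200 nM
- compound 3 `CC(=O)OCCO[C@H](CC=C(C)C)C1=CC(=O)c2c(O)ccc(O)c2C1=O`: 41500 nM

The three compounds share one core and differ only in the group attached through an oxygen on a saturated carbon. In a functional assay on HeLa cells (Homo sapiens) for cytotoxicity, read by MTT assay (a lower number here means a stronger inhibitor, a higher number a weaker inhibitor), compound 1 gives 53400 nM, compound 2 gives 72200 nM and compound 3 gives 41500 nM. Among the compounds with values here, compound 3 has the lowest of the three numbers, yet the gaps to its neighbours are small: a 1.3-fold lower number from compound 1 to compound 3 (0.11 log units; within the scatter) and a 1.7-fold lower number from compound 2 to compound 3 (0.24 log units; within the scatter), both within the scatter, so no compound can be called the strongest.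

Compound 4 `CCC(CO[C@H](CC=C(C)C)C1=CC(=O)c2c(O)ccc(O)c2C1=O)OC(C)=O` is not yet measured. The change from compound 3 is ethyl in place of hydrogen on a saturated chain carbon bound to an oxygen next to a carbonyl group and a saturated chain carbon. Every side-chain alteration so far, including a 1.4-fold higher number from compound 1 to compound 2 (0.13 log units; within the scatter), moved this assay by no more than the usual scatter, and nothing in these data singles out the ethyl addition as different in kind. The step of a 1.0-fold lower number from compound 3 to compound 4 (0.02 log units; within the scatter) is therefore expected to stay within the scatter. Compound 4 is estimated at 40000 nM, with a likely range from 20000 nM to 85000 nM.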

Compound 4, half-maximal inhibitory concentration: 44000 nM
For compound 4 the middle estimate is 1.1-fold (0.04 log units) below the measured one; the measured number falls inside the stated range.
By their numbers in this assay, from the lowest: compounds 3, 4, 1 and 2 (each within the scatter of the next).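

In this assay, ethyl in place of hydrogen on a saturated chain carbon bound to an oxygen next to a carbonyl group and a saturated chain carbon gives a 1.1-fold higher number from compound 3 to compound 4 (0.03 log units; within the scatter). Within the data shown here, this is the first single, small change at this carbon, and it shows that the 2-acetoxyethyl group can become 2-acetoxybutyl without a step beyond the scatter, whereas the earlier steps each swapped a larger part of the side chain. The 2-acetoxybutyl side chain also stays within the scatter of the other two side chains, with a 1.6-fold lower number from compound 2 to compound 4 (0.22 log units; within the scatter) and a 1.2-fold lower number from compound 1 to compound 4 (0.08 log units; within the scatter), and no supporting data here explain these close numbers.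

On these data alone, whether a longer chain, an amine or a carboxylic acid on this carbon would give a step beyond the scatter remains open. The compounds shown also leave open how the shared core would read with a free hydroxyl on this saturated carbon.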